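A few compounds are considered here, and "the series" means these few. Any claim that something is new, unique, unknown or untested is made for them only; others in the source may bear on it.

For the measured compounds named here, compound 2 `N#CC1(c2cc(CC(O)C(F)(F)F)cc(-c3ccnc4[nH]nc(C(F)(F)F)c34)c2)CC1` gives 267 nM in an assay on isolated protein for inhibition of protein kinase C epsilon type (Homo sapiens), read by coupled enzyme assay (a higher number here means a weaker inhibitor, a lower number a stronger inhibitor), the higher of the two numbers so far; compound 1 `N#CC1(c2cc(CC(O)C3CC3)cc(-c3ccnc4[nH]nc(C(F)(F)F)c34)c2)CC1` gives 30 nM in this assay. Going by the values given here, the one measured step, an 8.9-fold higher number from compound 1 to compound 2 (0.95 log units; beyond the scatter), sits on the carbon bearing the hydroxyl, one bond further out than the change to compound 3 `N#CC1(c2cc(CCF)cc(-c3ccnc4[nH]nc(C(F)(F)F)c34)c2)CC1`, which is fluoromethyl in place of 2,2,2-trifluoro-1-hydroxyethyl on a saturated chain carbon bound to an aromatic carbon. Among the compounds with values here, no measured step covers the loss of the hydroxyl together with the shorter chain; the single step shows only that this side of the core tolerates a change of modest size. For compound 3 the expected value in this assay is 160 nM, within 40 nM to 650 nM. The expected step is therefore a 1.7-fold lower number from compound 2 to compound 3 (0.22 log units; within the scatter), with no clear direction beyond the scatter.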

Compound 3, inhibition constant: 90 nM
Beside the measured number, compound 3's estimate is 1.8-fold (0.25 log units) above it, within the range that was stated.
By their numbers in this assay, from the lowest: compound 1; then compound 3; then compound 2.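

In this assay, a hydroxyl on this chain is not required for activity: fluoromethyl in place of 2,2,2-trifluoro-1-hydroxyethyl gives a 3.0-fold lower number from compound 2 to compound 3 (0.47 log units; beyond the scatter) while fluoromethyl in place of cyclopropyl(hydroxy)methyl gives a 3.0-fold higher number from compound 1 to compound 3 (0.48 log units; beyond the scatter) so the direction depends on the group that leaves. Nothing in the data shown accounts for either step. Open, on these data alone, is whether the fluorine of fluoromethyl matters, since a plain ethyl chain would separate it from chain shortening. Also open, as far as these compounds go, is how an amine or a longer chain would compare on this saturated chain carbon.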